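The source may report more compounds than this note shows. Statements on the series, on what has been measured and on what is new or still open speak of the compounds shown alone.

Compound 1 `Cc1nc(N)sc1CCCN/C(N)=N/C(=O)NC(C)c1cccc(F)c1` gives 26.3 nM in a functional assay on Right cardiac atrium for agonist activity at histamine H2 receptor (Cavia porcellus), with a stated time of 30 min, in the presence of a further agent that is not named here (a higher number here means that more compound is needed for the effect, a lower number that less compound is needed), and compound 3 `Cc1nc(N)sc1CCCN/C(N)=N/C(=O)N[C@@H](C)c1ccccc1` gives 23.4 nM. Compound 2 `Cc1nc(N)sc1CCCN/C(N)=N/C(=O)NC(C)c1ccc(Br)cc1` gives 55 nM, the highest of the three numbers, with compound 1 nearest and compound 3 furthest from it. Among the compounds with values here, the one measured step, a 2.1-fold higher number from compound 1 to compound 2 (0.32 log units; beyond the scatter), was modest. Compound 4 `Cc1nc(N)sc1CCCN/C(N)=N/C(=O)NC(C)c1ccc(OC(F)(F)F)cc1` differs from compound 2 in one place: trifluoromethoxy in place of bromo on an aromatic carbon. Within the data shown here, no measured step exchanges a bromo for a trifluoromethoxy, so the earlier step is only a loose guide to how much the number on this ring may move. The expected step is a 1.1-fold lower number from compound 2 to compound 4 (0.04 log units; within the scatter). Compound 4 is therefore estimated at 50 nM, within a range from 15 nM to 160 nM.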

Compound 4, half-maximal effective concentration: 724 nM
Compound 4: the middle estimate sits 14-fold (1.16 log units) below what was measured; measured number above the stated range.
By their numbers in this assay, from the lowest: compounds 3 and 1 (each within the scatter of the next); then compound 2; then compound 4.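

In this assay, trifluoromethoxy in place of bromo on this aromatic carbon brings a 13-fold higher number from compound 2 to compound 4 (1.12 log units; beyond the scatter), a much larger move than the earlier 2.1-fold higher number from compound 1 to compound 2 (0.32 log units; beyond the scatter). This position, para to a large group, therefore does not accept every substituent equally, and two groups that might look interchangeable on paper can give very different numbers. Nothing measured here accounts for the difference. Still open, from the compounds shown here alone, is whether methoxy or trifluoromethyl at this place would stay close to compound 2 or move toward compound 4. That comparison would show which part of the trifluoromethoxy group goes with the higher number.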